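The source may report more compounds than this note shows. Statements on the series, on what has been measured and on what is new or still open speak of the compounds shown alone.

Compound 2, `CNc1nccc(N2CC[C@H](NC(=O)Nc3ccc(C)c(Cl)c3)C2)n1`, is one of three compounds that have so far been measured in a physicochemical assay for solubility, measured as kinetic solubility; on this read-out higher numbers stand for higher solubility and lower numbers for lower solubility. In this assay compound 2 gives 72700 nM. Compound 3, `CNc1nccc(N2CC[C@H](NC(=O)Nc3ccc(OC(F)F)cc3)C2)n1`, gives 92800 nM, a number that lies within the scatter of the value of compound 2, so the two cannot be ranked against each other. Compound 1, `Nc1nccc(N2CC[C@H](NC(=O)Nc3ccc(Cl)c(C(F)(F)F)c3)C2)n1`, gives 30300 nM, which lies beyond the scatter from compound 2 and leaves compound 2 with the second highest of the three numbers. Among the compounds with values here, no two of the measured compounds differ from each other in only one place, so no step between measured compounds can be stated and no pattern can be drawn from them.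

Compound 4, `CNc1nccc(N2CC[C@H](NC(=O)Nc3cccc(C#N)c3)C2)n1`, is yet to be measured in this assay. It differs from compound 2 in one place: 3-cyanophenyl in place of 3-chloro-4-methylphenyl on an amide-type nitrogen. Within the data shown here, with no measured step of this kind to lean on, the expectation rests on the position of compound 2 alone. In this assay the step of a 1.7-fold higher number from compound 2 to compound 4 (0.22 log units; within the scatter) is expected to be a modest rise, likely at the edge of the scatter. Compound 4 is therefore estimated at 120000 nM, with a range from 60000 nM to 250000 nM.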

Compound 4, solubility: 95700 nM
Estimate against measurement, compound 4: 1.3-fold (0.10 log units) above, within the range that was stated.
By their numbers in this assay, from the lowest: compound 1; then compounds 2, 3 and 4 (each within the scatter of the next).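

In this assay, the first step measured at this place, on the amide-type nitrogen, reads a 1.3-fold higher number from compound 2 to compound 4 (0.12 log units; within the scatter), so compound 2 and compound 4 cannot be ranked against each other. The exchange keeps the same number of heavy atoms and the six-membered aromatic ring of carbon only, while a chlorine and a methyl group leave and a nitrile enters, bringing in a hydrogen-bond acceptor, and the read-out does not separate the two aryl groups. No measurement at hand bears on why this exchange gives the result it does.

The compounds shown leave open whether any change at this place can carry the number beyond the scatter, as a carboxylic acid or a dimethylamino group on the phenyl ring might or might not do. They also leave open whether the exchange of 3-chloro-4-methylphenyl for 3-cyanophenyl would read the same way on a core that carries a longer chain, such as an ethylamino group, in place of the methylamino group.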